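Two Limits and an Aryl Swap on the Triazole Nitrogen

The compounds below may be only part of what the source reports. "The series", "measured", "known", "first", "only" and "open" are said of these compounds alone.

Compound 1, `Cc1ccc(-n2nncc2CN2C(=O)C3(C(C#N)=C(N)Oc4c3c3nc5ccccc5nc3c3ccccc43)c3ccccc32)c(C)c1` — > 50000 nM
Compound 2, `N#CC1=C(N)Oc2c(N)cc3nc4ccccc4nc3c2C12C(=O)N(Cc1cnnn1-c1ccc(Cl)cc1)c1ccccc12` — > 50000 nM

In an ADME assay on HUVEC cells (Homo sapiens) for antiproliferative activity, read by MTT assay, with a stated time of 48 h (a higher number here means a weaker inhibitor, a lower number a stronger inhibitor), compound 1 returns only a limit, > 50000 nM. In this assay compound 2 likewise returns only a limit, > 50000 nM. Going by the values given here, neither value is a number, so no step between the two measured compounds can be drawn; both simply sit at the limit of > 50000 nM in this assay, at which 2 of the 2 values shown sit.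

Compound 3, `CCc1cccc(C)c1-n1nncc1CN1C(=O)C2(C(C#N)=C(N)Oc3c(N)cc4nc5ccccc5nc4c32)c2ccccc21`, is the next candidate for this assay. It differs from compound 2 by a single change on the aromatic nitrogen of the five-membered aromatic ring with three nitrogens: 2-ethyl-6-methylphenyl in place of 4-chlorophenyl on an aromatic nitrogen.

Among the compounds with values here, with both measured compounds at the limit and no measured step to lean on, the expected step that the limit leaves unreadable from compound 2 to compound 3 is none beyond the scatter. Compound 3 is therefore estimated at 80000 nM, within 30000 nM to 300000 nM, and most likely reported as a limit.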

Compound 3, half-maximal inhibitory concentration: > 50000 nM
Compound 3 was reported as a limit; the forecaster's own chance of this, stated with the estimate: 85%; the middle value does not contradict the limit.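

No step can be read from compound 2 to compound 3, with 2-ethyl-6-methylphenyl in place of 4-chlorophenyl on an aromatic nitrogen, and both results are limits, not numbers: the limit of > 50000 nM in this assay, at which 3 of the 3 values shown sit.

The compounds shown leave open whether the group on that nitrogen matters in this assay, and how compound 1, compound 2 and compound 3 rank there.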